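The compounds below may be only part of what the source reports. "The series", "measured", "known", "first", "only" and "open" are said of these compounds alone.

Measured compounds:
- compound 1, `CCOC(=O)c1sc(-c2cccc(NC(=O)c3ccc(C(C)(C)C)cc3)c2)nc1Nc1ccc(N2CCN(C)CC2)cc1`: 21.2%
- compound 2, `CCOC(=O)c1sc(-c2cccc(NC(=O)c3ccc(C(F)(F)F)cn3)c2)nc1Nc1ccc(N2CCN(C)CC2)cc1`: 19%

Both compounds were tested in a functional assay on Ramos cells (Homo sapiens) for antiproliferative activity, read by CCK-8 assay, with a stated time of 72 h, tested at 40 uM; on this read-out higher numbers stand for more inhibition at the one concentration tested (going by the name of the read-out) and lower numbers for less inhibition. Compound 1 gives 21.2% and compound 2 gives 19%, and the step of a number 2.2 percentage points lower from compound 1 to compound 2 (within the scatter) is within the scatter, so the two numbers cannot be told apart; compound 1 stands with compound 2 at a modest level of inhibition.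

Compound 3, `CN1CCN(c2ccc(Nc3nc(-c4cccc(NC(=O)c5ccc(C(C)(C)C)cc5)c4)sc3C(N)=O)cc2)CC1`, has not yet been measured. It differs from compound 1 in one place: amino in place of ethoxy on a carbonyl carbon. Within the data shown here, the only measured step, the exchange of 5-(trifluoromethyl)pyridin-2-yl for 4-(tert-butyl)phenyl on a carbonyl carbon, touches a different part of the shared core and says nothing about this change. Among the measured compounds shown here, no measured step bears on it. With nothing to point either way, compound 3 is expected to stay near compound 1, with a step of a number 0.2 percentage points lower from compound 1 to compound 3 (within the scatter) that is not expected to exceed the scatter. The estimate for compound 3 is 21%, ranging from 5% to 40%.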

Compound 3, a percentage reported as inhibition, at one concentration (the size of the read-out at that concentration, not a potency): 80.1%
Compound 3: the middle estimate sits 59.1 percentage points below what was measured; measured number above the stated range.
By their numbers in this assay, from the lowest: compounds 2 and 1 (each within the scatter of the next); then compound 3.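

In this assay, the carbonyl carbon bearing the ethoxy group emerges as a place where a single exchange matters greatly: amino in place of ethoxy gives a number 58.9 percentage points higher from compound 1 to compound 3 (beyond the scatter). The earlier step, a number 2.2 percentage points lower from compound 1 to compound 2 (within the scatter), changed a different place and stayed within the scatter, so it gave no sign of such sensitivity anywhere on the molecule. The exchange, read as ethoxycarbonyl to carbamoyl, replaces three heavy atoms with one and brings in a hydrogen-bond donor, but nothing available shows which feature of the change accounts for the higher number.

The compounds shown leave open whether the higher inhibition is specific to the carbamoyl group or would also appear with a carboxylic acid, a nitrile or a methylamino group on that carbonyl carbon. They also leave open whether the same exchange would raise the number when 5-(trifluoromethyl)pyridin-2-yl replaces 4-(tert-butyl)phenyl.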